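A few compounds are considered here, and "the series" means these few. Any claim that something is new, unique, unknown or untested is made for them only; others in the source may bear on it.

Series notes. Among the compounds with values here, compound 2 `N#CC1=C(N)Oc2c(c3nc4ccccc4nc3c3ccccc23)C12C(=O)N(Cc1cnnn1-c1ccc(S(N)(=O)=O)cc1)c1ccccc12` is the one member of the set that gives a number rather than a limit: in a functional assay on HCT-116 cells (Homo sapiens) for antiproliferative activity, read by MTT assay, with a stated time of 48 h (a lower number here means a stronger inhibitor, a higher number a weaker inhibitor), compound 2 gives 31200 nM. Compound 1 `Cc1cccc(-n2nncc2CN2C(=O)C3(C(C#N)=C(N)Oc4c3c3nc5ccccc5nc3c3ccccc43)c3ccccc32)c1` reaches only a limit, > 50000 nM in this assay. Within the data shown here, the single measured step is therefore known only as a floor: an at least 1.6-fold lower number from compound 1 to compound 2 (0.20 log units; that floor lies within the scatter), resting on (the limit of > 50000 nM in this assay, at which 1 of the 2 values shown sits). Compound 3 `Cc1ccc(C)c(-n2nncc2CN2C(=O)C3(C(C#N)=C(N)Oc4c3c3nc5ccccc5nc3c3ccccc43)c3ccccc32)c1` changes the same aromatic nitrogen again: 2,5-dimethylphenyl in place of 4-sulfamoylphenyl on an aromatic nitrogen. The measured step runs the other way, from a methyl-bearing phenyl to the sulfamoylphenyl, so the return to a methyl-bearing phenyl is read as the reverse of that floor. For compound 3 a rise in this assay is expected, a 1.6-fold higher number from compound 2 to compound 3 (0.20 log units; within the scatter). Compound 3 is estimated at 50000 nM in this assay, with a range of 20000 nM to 150000 nM and a fair chance of a limit only.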

Compound 3, half-maximal inhibitory concentration: > 50000 nM
Compound 3 was reported as a limit; the forecaster's own chance of this, stated with the estimate: 50%; the middle value sits exactly at the limit.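

In this assay, 2,5-dimethylphenyl in place of 4-sulfamoylphenyl gives an at least 1.6-fold higher number from compound 2 to compound 3 (0.20 log units; that floor lies within the scatter). Within the data shown here, both methyl-bearing phenyl groups at this aromatic nitrogen now end in a limit, and 4-sulfamoylphenyl remains the only group here with a number. The step for the added methyl cannot be read, and every comparison stays a floor at best: the limit of > 50000 nM in this assay, at which 2 of the 3 values shown sit.

From the compounds shown here alone, whether the sulfamoyl group itself matters remains open, since a floor within the scatter cannot settle it. Also open, going by these compounds, is whether a phenyl bearing an amine or a carboxylic acid at this nitrogen would give a number.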